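Amide to methyl ester in the hexenyl pyridine series

The compounds below may be only part of what the source reports. "The series", "measured", "known", "first", "only" and "open" are said of these compounds alone.

Three compounds have numbers in an assay (Equus caballus) for inhibition of Thromboxane-A synthase (Homo sapiens), using microsomes; on this read-out higher numbers stand for weaker inhibition and lower numbers for stronger inhibition. Compound 1 `O=C(O)CCCC/C=C\c1cccnc1` gives 250 nM in this assay, compound 3 `O=C(O)CCCC/C=C(/c1cccnc1)c1ccsc1` gives 62 nM, and compound 2 `NC(=O)CCCC/C=C(\c1ccccc1)c1cccnc1` gives 400 nM. Compound 2 thus carries the highest number of the three; its gap to compound 1 lies within the usual scatter, while the gap to compound 3 lies beyond it. Compound 4 `COC(=O)CCCC/C=C(\c1ccccc1)c1cccnc1` differs from compound 2 by methoxy in place of amino on a carbonyl carbon. Within the data shown here, no measured pair shows this change, so nothing in hand sets its size or direction; a step within the scatter, or none at all, is the working expectation. The expected step from compound 2 to compound 4 in this assay is a 1.3-fold higher number from compound 2 to compound 4 (0.10 log units; within the scatter). Compound 4 is accordingly estimated at 500 nM, with a range from 150 nM to 1700 nM.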

Compound 4, half-maximal inhibitory concentration: 100 nM
Compound 4: middle estimate off by 5.0-fold (0.70 log units), on the high side; the whole stated range lies above it.
By their numbers in this assay, from the lowest: compounds 3 and 4 (each within the scatter of the next); then compounds 1 and 2 (each within the scatter of the next).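

Methoxy in place of amino on a carbonyl carbon now has a measured size: in this assay it gives a 4.0-fold lower number from compound 2 to compound 4 (0.60 log units; beyond the scatter) on the shared core. What sits on this carbonyl carbon therefore moves the read-out beyond the scatter, and here the amide is the weaker of the two. No measurement at hand gives a reason for this step.

Open, as far as these compounds go, is where the carboxylic acid on the core of compound 2 would fall relative to compound 4. Also open, from the compounds shown here alone, is whether an ethoxycarbonyl group would read like methoxycarbonyl at this place.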